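The source may hold more compounds than are shown below. What is called first, only, known or untested is meant among the compounds shown, and "the series" means these compounds.

Of the compounds shown here, three have been tested so far in a functional assay on K562 cells (Homo sapiens) for inhibition, read by thymidine incorporation, with a stated time of 48 h, tested at 10 ug/mL; a higher number here means more inhibition at the concentration tested (going by the name of the read-out), a lower number less inhibition. Compound 1 `C(#Cc1ncnc2c1ncn2Cc1ccccc1)c1ccccc1` gives 98% in this assay. Compound 2 `OC[C@H]1OC(n2cnc3c(C#Cc4ccccc4)ncnc32)[C@H](O)[C@@H]1O` gives 100% in this assay, and compound 3 `C=Cc1ncnc2ncn(Cc3ccccc3)c12` gives 100% in this assay. Compound 2 thus stands level with compound 3 at the digits reported, and the two together hold the highest numbers of the three, while the number for compound 1 differs from theirs only within the usual scatter of repeated measurements, so the three cannot be told apart. No pair of these compounds differs in a single place, so no step between measured compounds can be read off.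

Compound 4 `OC[C@H]1OC(n2cnc3c(/C=C/c4ccccc4)ncnc32)[C@H](O)[C@@H]1O` has not yet been measured. It differs from compound 2 in one place: 2-phenylethenyl in place of 2-phenylethynyl on an aromatic carbon. Going by the values given here, since every measured compound sits at a high number in this assay and no step between them is available, the measured numbers give no direction to read from; the step from compound 2 to compound 4 is expected to be a number 4 percentage points lower from compound 2 to compound 4 (within the scatter), nothing beyond the scatter. Compound 4 is estimated to give 96% in this assay, within a range from 82% to 100%.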

Compound 4, a percentage reported as inhibition, at one concentration (the size of the read-out at that concentration, not a potency): 79%
The estimate for compound 4 lay 17 percentage points above the measured number; the whole stated range lies above it.
By their numbers in this assay, from the lowest: compound 4; then compounds 1, 2 and 3 (each within the scatter of the next).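

Going by these compounds alone, until now every compound sat so high in this assay that none could be told apart, and this change on the aromatic carbon gives the first step that can be read: 2-phenylethenyl in place of 2-phenylethynyl gives a number 21 percentage points lower from compound 2 to compound 4 (beyond the scatter) at the one concentration tested. The two groups have the same count of heavy atoms and the same six-membered aromatic ring of carbon only, and they differ in a triple bond against a double bond outside that ring, so the read-out at this position responds to that single difference in the link, and the position does not accept both links alike. Nothing available explains why the read-out falls with the double bond in place of the triple bond.

The compounds shown leave open how a saturated link would compare at this carbon, as in 2-phenylethyl, or a group of a different kind, such as an amine or a longer chain ending in a carboxylic acid. They also leave open whether the same swap would give a step of similar size on the core of compound 1, where a benzyl group stands in place of the sugar-like ring of compound 2.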